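Swapping a methyl for dimethylamino on a benzylidene thiazolidinone

The compounds below may be only part of what the source reports. "The series", "measured", "known", "first", "only" and "open" are said of these compounds alone.

Three compounds share one core. Compound 1 `O=C1CS/C(=N\c2csc(-c3ccccc3)c2)N1` is that bare core without a benzylidene arm. In a functional assay on HT-29 cells (Homo sapiens) for cytotoxicity, read by MTT assay, with a stated time of 72 h (on this read-out lower numbers stand for stronger inhibition and higher numbers for weaker inhibition), compound 1 gives > 50000 nM, which is a limit of the assay rather than a number: the limit of > 50000 nM in this assay, at which 1 of the 3 values shown sits. Compound 2 `COc1ccc(/C=C2\S/C(=N\c3csc(-c4ccc(Cl)cc4)c3)NC2=O)cc1` carries a methoxy on its outer ring and gives 3800 nM in this assay. Compound 3 `Cc1ccc(/C=C2\S/C(=N\c3csc(-c4ccc(Cl)cc4)c3)NC2=O)cc1` carries a methyl in the same spot and gives 6400 nM in this assay. For the measured compounds named here, the only one-place step measured so far, a 1.7-fold higher number from compound 2 to compound 3 (0.23 log units; within the scatter), is too small to call a real difference. Compound 3 therefore holds the higher of the two numbers, with compound 2 the nearest neighbour and effectively level with it, while the third value is a limit.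

Compound 4 `CN(C)c1ccc(/C=C2\S/C(=N\c3csc(-c4ccc(Cl)cc4)c3)NC2=O)cc1` differs from compound 3 by dimethylamino in place of methyl on an aromatic carbon. Going by the values given here, no measured step introduces a dimethylamino, so the only guide is the methoxy-to-methyl swap, which barely moved the number. A change on the same outer carbon is expected to behave similarly, giving an estimated 1.8-fold lower number from compound 3 to compound 4 (0.26 log units; within the scatter), at most a modest shift toward a lower number. Compound 4 is therefore estimated at 3500 nM in this assay, within a range from 1000 nM to 12000 nM.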

Compound 4, half-maximal inhibitory concentration: 1500 nM
Compound 4: the middle estimate sits 2.3-fold (0.37 log units) above what was measured; low and high end bracket the measured number.
By their numbers in this assay, from the lowest: compound 4; then compounds 2 and 3 (each within the scatter of the next). At a limit, above all of these: compound 1.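

This position on the outer ring can clearly move the number: in this assay, dimethylamino in place of methyl gives a 4.3-fold lower number from compound 3 to compound 4 (0.63 log units; beyond the scatter) and so clears the usual scatter, which the swap between methoxy and methyl did not do. Dimethylamino also separates from methoxy, with a 2.5-fold lower number from compound 2 to compound 4 (0.40 log units; beyond the scatter) on the same carbon, so of the three groups shown here it gives the lowest number, while the methoxy and methyl compounds stay level with each other. Both new steps are modest, and nothing measured here explains what about the dimethylamino group produces them.

As far as these compounds go, it remains open whether the change follows the nitrogen itself or the two methyl groups it carries, and a plain amino group or a diethylamino group on this carbon would help to separate those two readings. A carboxylic acid or a hydroxyl in the same spot would show whether lower numbers also appear with groups of a different kind, and every comparison here still rests on a single cell line.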